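Para methyl for fluoro on the aryl-bearing series

A few compounds are considered here, and "the series" means these few. Any claim that something is new, unique, unknown or untested is made for them only; others in the source may bear on it.

Three compounds have numbers in an assay on isolated protein for inhibition of lysosomal alpha-glucosidase (Rattus norvegicus), read by colorimetric assay (on this read-out lower numbers stand for stronger inhibition and higher numbers for weaker inhibition), so far. Compound 1 `OC[C@]1(c2ccc(F)cc2)NC[C@H](O)[C@H]1O` gives 101000 nM in this assay, the second highest of the three. Compound 3 `OC[C@@]1(c2cccc(F)c2)NC[C@@H](O)[C@@H]1O` gives 216000 nM in this assay, a higher number than compound 1 and beyond the scatter. Going by the values given here, compound 2 `C[C@]1(CO)NC[C@@H](O)[C@@H]1O` gives 830 nM in this assay, far lower than both; compound 2 carries a methyl rather than an aryl group on the shared core, so no single-point step connects it to compound 1 or compound 3.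

Compound 4 `Cc1ccc([C@@]2(CO)NC[C@H](O)[C@H]2O)cc1` is not yet measured in this assay. It differs from compound 1 by methyl in place of fluoro on an aromatic carbon. Among the compounds with values here, no measured pair shows this exchange, so its size cannot be read from the data. Compound 1 and compound 3 show that an aryl group at this position of the core leaves the number high whichever ring carbon carries the fluoro. On that basis the step from compound 1 to compound 4 is expected to stay within the scatter, with no direction of change claimed, a 1.1-fold higher number from compound 1 to compound 4 (0.04 log units; within the scatter). Compound 4 is estimated at 110000 nM in this assay, within 35000 nM to 350000 nM.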

Compound 4, half-maximal inhibitory concentration: 17000 nM
Estimate against measurement, compound 4: 6.5-fold (0.81 log units) above; measured number below the stated range.
By their numbers in this assay, from the lowest: compound 2; then compound 4; then compound 1; then compound 3.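

In this assay, going by these compounds alone, methyl in place of fluoro on an aromatic carbon, para to a group of 9 heavy atoms, gives a 5.9-fold lower number from compound 1 to compound 4 (0.77 log units; beyond the scatter) as the first single-point step. This position is therefore not silent: the number of an aryl-bearing compound can move beyond the scatter with an exchange of one heavy atom, with no hydrogen-bond donor or acceptor entering or leaving. Nothing measured here accounts for the size or direction of this step.

From the compounds shown here alone, whether chloro, ethyl or methoxy on the same aromatic carbon would extend the step or reverse it remains open. Also open, going by these compounds, is whether methyl would give a similar step on the ring carbon that carries the fluoro in compound 3.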